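A few compounds are considered here, and "the series" means these few. Any claim that something is new, unique, unknown or untested is made for them only; others in the source may bear on it.

Values in a physicochemical assay for lipophilicity (on this read-out higher numbers stand for higher lipophilicity and lower numbers for lower lipophilicity), for the three measured compounds
- compound 1 (`O=S(=O)(Nc1ncccn1)c1ccc2c(c1)OCC[C@@H]2c1ccc(C(F)(F)F)cc1-c1ccc(F)nc1`) gives 2.8
- compound 2 (`Cc1ccc(-c2cc(C(F)(F)F)ccc2[C@H]2CCOc3cc(S(=O)(=O)Nc4ncc(F)cn4)ccc32)cn1`) gives 2.5
- compound 3 (`O=S(=O)(Nc1nccs1)c1ccc2c(c1)OCC[C@@H]2c1ccc(C(F)(F)F)cc1-c1ccc(F)cc1`) gives 4.5

Compound 3 stands highest of the three at 4.5 in this assay and lies above both other compounds by margins beyond the usual scatter. The next compound to be examined, compound 4 (`O=S(=O)(Nc1nccs1)c1ccc2c(c1)OCC[C@@H]2c1ccc(C(F)(F)F)cc1N1CCNCC1`), differs from compound 3 in one place. It carries piperazin-1-yl in place of 4-fluorophenyl on an aromatic carbon, ortho to a large group and meta to a trifluoromethyl group.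

Going by the values given here, no two measured compounds differ in one place alone, so no measured step gauges this change directly. Compound 1 at 2.8 and compound 2 at 2.5 sit well under compound 3 in their values, but each differs from it in more than one place and offers only a loose guide. On the structural change, a large downward step well beyond the scatter is expected in this assay for this replacement. The expected size of the change is a number 2.20 log units lower from compound 3 to compound 4 (beyond the scatter) as estimated here. For compound 4 the estimated value is 2.3 with an expected range from 1.6 to 3 in this read-out.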

Compound 4, distribution coefficient: 1.4
The estimate for compound 4 lay 0.90 log units above the measured number; measured number outside the range, below it.
By their numbers in this assay, from the lowest: compound 4; then compounds 2 and 1 (each within the scatter of the next); then compound 3.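

In this assay, putting piperazin-1-yl in place of 4-fluorophenyl on this aromatic carbon, ortho to a large group and meta to a trifluoromethyl group, gives a number 3.10 log units lower from compound 3 to compound 4 (beyond the scatter). This is the first step among the compounds shown that isolates a single place, and it shows that this one replacement alone is enough to produce a large change in the read-out, which the earlier compounds, each differing from compound 3 in more than one place, could not show. The pair cannot separate the contributions of the departing aromatic ring, the entering nitrogens and the entering hydrogen-bond donor, and nothing available accounts for the size of the step.

The compounds shown leave open how the read-out would respond at this position to other groups, such as morpholin-4-yl, 4-methylpiperazin-1-yl or an open-chain amine. They also leave open whether piperazin-1-yl would give a step of similar size on the sulfonamide partners carried by compound 1 and compound 2.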